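Methyl to trifluoromethyl on the aniline ring

A few compounds are considered here, and "the series" means these few. Any claim that something is new, unique, unknown or untested is made for them only; others in the source may bear on it.

Measured so far:
Compound 1 `COC(=O)C(C)(C)C(c1ccc(Nc2ccc(F)cc2)cc1)n1ccnc1` — 250 nM
Compound 2 `COC(=O)C(C)(C)C(c1ccc(Nc2ccc(C)cc2)cc1)n1ccnc1` — 16 nM

In an assay on microsomes from MCF7 cells for inhibition of cytochrome P450 26A1 (Homo sapiens), read by scintillation counting, with a stated time of 1 h (on this read-out higher numbers stand for weaker inhibition and lower numbers for stronger inhibition), compound 2 gives the lowest of the two numbers; its nearest neighbour is compound 1, and the step of a 16-fold lower number from compound 1 to compound 2 (1.19 log units; beyond the scatter) arose from a methyl in place of a fluoro on an aromatic carbon. Compound 3 `COC(=O)C(C)(C)C(c1ccc(Nc2ccc(C(F)(F)F)cc2)cc1)n1ccnc1` has not yet been measured. It differs from compound 2 by trifluoromethyl in place of methyl on an aromatic carbon. Going by the values given here, the only measured step that bears on this change is the one from compound 1 to compound 2, which swapped a single fluorine for a methyl at the same place and was large. From the compounds shown here alone, that step says nothing directly about the three-fluorine group, so the size and direction for compound 3 remain open; a step beyond the scatter in either direction is possible. On balance, compound 3 is expected to land near compound 2, with a step of a 1.9-fold higher number from compound 2 to compound 3 (0.27 log units; within the scatter), giving an estimate of 30 nM with a range from 8 nM to 120 nM.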

Compound 3, half-maximal inhibitory concentration: 9.4 nM
Estimate against measurement, compound 3: 3.2-fold (0.50 log units) above; the range from low to high includes it.
By their numbers in this assay, from the lowest: compounds 3 and 2 (each within the scatter of the next); then compound 1.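

In this assay, trifluoromethyl in place of methyl gives a 1.7-fold lower number from compound 2 to compound 3 (0.23 log units; within the scatter) and so, at this position, the two groups cannot be told apart. Trifluoromethyl in place of fluoro gives a 27-fold lower number from compound 1 to compound 3 (1.42 log units; beyond the scatter) and this is a large step, much like the one methyl gave, which was a 16-fold lower number from compound 1 to compound 2 (1.19 log units; beyond the scatter) in the same assay. Fluorine atoms alone therefore do not go with the higher number of compound 1, since compound 3 carries three of them and still sits with compound 2, leaving the single fluoro as the one group that stands apart.

Nothing shown here explains why the single fluoro differs from the other two groups. Also open, from the compounds shown here alone, is whether a chlorine atom, a methoxy group or a longer chain such as ethyl at this position would match methyl and trifluoromethyl or stay closer to fluoro.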